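Fluoro for methyl on the lactam aryl ring

This account rests on a few compounds, and the source may have more. Where it says the series, first, only, none or still open, it means among the compounds named here.

Compound 3 `Cc1ccc(N2CC(c3nc(-c4cccc(F)c4)no3)CC2=O)cc1` gives 1200 nM in an in vitro functional assay on HEK293-A cells for positive allosteric modulation of metabotropic glutamate receptor 5 (Homo sapiens), read by FLIPR and calcium flux (a lower number here means that less compound is needed, a higher number that more compound is needed for the effect), the highest of the two numbers recorded there. Compound 2 `O=C1CC(c2nc(-c3ccccc3)no2)CN1c1ccc(F)cc1` gives 58 nM in this assay. For compound 1 `Cc1cccc(-c2noc(C3CC(=O)N(c4ccc(F)cc4)C3)n2)n1` this assay reports only a limit, > 10000 nM, and no number. Within the data shown here, the one measured step, an at least 170-fold lower number from compound 1 to compound 2 (2.23 log units; beyond the scatter), concerns the aryl group attached to the heteroaromatic ring, not the ring on the lactam nitrogen, so it does not speak directly to the change at hand.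

Compound 4 `O=C1CC(c2nc(-c3cccc(F)c3)no2)CN1c1ccc(F)cc1` differs from compound 3 by fluoro in place of methyl on an aromatic carbon, on an aromatic carbon of a six-membered aromatic ring of carbon only, para to a large group. Compound 4 carries the same 4-fluorophenyl on the lactam nitrogen as compound 2, and the same 3-fluorophenyl on the other end as compound 3. Compound 4 is therefore expected to sit between those two, closer to compound 2, with an estimated 150 nM in this assay, ranging from 40 nM to 600 nM. That estimate amounts to an expected step of an 8.0-fold lower number from compound 3 to compound 4 (0.90 log units; beyond the scatter).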

Compound 4, half-maximal effective concentration: 88 nM
For compound 4 the middle estimate is 1.7-fold (0.23 log units) above the measured one; low and high end bracket the measured number.
By their numbers in this assay, from the lowest: compounds 2 and 4 (each within the scatter of the next); then compound 3. At a limit, above all of these: compound 1.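

In this assay, among these compounds, the change from 4-methylphenyl to 4-fluorophenyl proves large, and no earlier step had touched this ring: a 14-fold lower number from compound 3 to compound 4 (1.13 log units; beyond the scatter). With 4-fluorophenyl held fixed, fluoro in place of hydrogen on the other aryl group does not separate the two compounds, with a 1.5-fold higher number from compound 2 to compound 4 (0.18 log units; within the scatter). Compound 1 stands at a limit of the assay and not at a number, so 3-fluorophenyl in place of 6-methylpyridin-2-yl can be read only as a bound, an at least 110-fold lower number from compound 1 to compound 4 (2.05 log units; beyond the scatter): the limit of > 10000 nM in this assay, at which 1 of the 4 values shown sits.

The compounds shown leave open whether the gain from methyl to fluoro holds with plain phenyl on the other end. They also leave open how chloro, methoxy or hydrogen on the same aromatic carbon would compare with fluoro and methyl.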